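The compounds below may be only part of what the source reports. "The series", "measured", "known", "first", "only" and "open" are said of these compounds alone.

Compound 1 `O=C1COc2ccc(-c3cccc(NS(=O)(=O)c4ccc(F)cc4)c3)cc2N1` is the starting point. Among the measured compounds shown here, in a functional assay on MCF7 cells (Homo sapiens) for antiproliferative activity, read by MTT assay, with a stated time of 72 h (a lower number here means a stronger inhibitor, a higher number a weaker inhibitor), compound 1 gives 18300 nM, the only true number available so far. Compound 2 `COc1cccc(N2C(=O)COc3ccc(-c4cnc(OC)c(NS(=O)(=O)c5ccc(F)cc5)c4)cc32)c1` reads > 40000 nM, which is a limit of the assay and not a number. Compound 1 therefore has no second number against which to be ranked.

Compound 3 `O=C1COc2ccc(-c3cccc(NS(=O)(=O)c4ccc(F)cc4)c3)cc2N1C1CCCCC1` keeps the core of compound 1 and changes it in one place: cyclohexyl in place of hydrogen on an amide-type nitrogen in a ring. In words, cyclohexyl stands in place of hydrogen on an amide-type nitrogen in a ring.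

For the measured compounds named here, no measured pair of compounds shows what a change of this kind does, so any forecast rests on thin ground. In this assay, the expectation is no step beyond the usual scatter, with only a slight lean towards weaker inhibition. The estimated step of a 1.2-fold higher number from compound 1 to compound 3 (0.08 log units; within the scatter) is accordingly small, though a result reported only as a limit would not be surprising. Compound 3 is expected at 22000 nM, with an estimated range from 8000 nM to 40000 nM.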

Compound 3, half-maximal inhibitory concentration: 21400 nM
Compound 3: the middle estimate sits 1.0-fold (0.01 log units) above what was measured, within the range that was stated.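

Among the compounds shown here, the first measured step at this position, in this assay, is a 1.2-fold higher number from compound 1 to compound 3 (0.07 log units; within the scatter). Placing cyclohexyl on the amide-type nitrogen in a ring therefore gives a compound that cannot be told apart from its parent in this read-out, and compound 3 still returns a true number and not a limit. Compound 2 is the one compound reported as a limit and not a number, and because it differs from compound 1 in more than one place, it cannot show on its own what this nitrogen tolerates: the limit of > 40000 nM in this assay, at which 1 of the 3 values shown sits.

For the compounds shown here, this single step shows only that one group, cyclohexyl, leaves the value within the scatter, so it remains open whether this holds for a methyl, a benzyl, or a longer chain ending in an amine or a carboxylic acid at the same nitrogen. On these data alone, both compounds with true numbers are also weak inhibitors in this assay, and it remains open whether any change to the shared core, such as a different group in place of the fluorine on the sulfonamide's benzene ring, would move the value beyond the scatter.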